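Swapping bromo for methylsulfanyl on a prostaglandin receptor ligand

A few compounds are considered here, and "the series" means these few. Any claim that something is new, unique, unknown or untested is made for them only; others in the source may bear on it.

Of the compounds shown here, three sharing one core have been tested in an assay on isolated protein for inhibition of prostaglandin E2 receptor EP1 subtype (Homo sapiens); a lower number here means a stronger inhibitor, a higher number a weaker inhibitor. Compound 1 `O=C(O)c1cccc(C2=C(c3cc(Br)ccc3OCc3ccc(F)cc3)CCC2)c1` gives 20 nM in this assay. Compound 2 `CSc1ccc(OCc2ccc(F)cc2)c(C2=C(c3cccc(C(=O)O)c3)CCC2)c1` differs from compound 1 only by methylsulfanyl in place of bromo on an aromatic carbon, and in this assay compound 2 gives 31.6 nM; that change made a 1.6-fold higher number from compound 1 to compound 2 (0.20 log units; within the scatter). Compound 3 `O=C(O)c1cccc(C2=C(c3cc(Br)ccc3OCc3ccccc3)CCC2)c1` differs from compound 1 by hydrogen in place of fluoro on an aromatic carbon, and in this assay compound 3 gives 12.6 nM, a step of a 1.6-fold lower number from compound 1 to compound 3 (0.20 log units; within the scatter). Compound 3 carries the lowest of the three numbers, though its gap to compound 1 stays within the scatter; only its gap to compound 2 lies beyond it.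

Compound 4 `CSc1ccc(OCc2ccccc2)c(C2=C(c3cccc(C(=O)O)c3)CCC2)c1` has not yet been measured in this assay. It differs from compound 3 by methylsulfanyl in place of bromo on an aromatic carbon. This is the same kind of change as the one from compound 1 to compound 2, and it occurs twice among these compounds; the surroundings differ in that the group entering compound 4 sits para to a benzyloxy group, whereas in compound 2 it sits para to a (4-fluorobenzyl)oxy group. Starting from compound 3, the change is expected to produce a 1.6-fold higher number from compound 3 to compound 4 (0.20 log units; within the scatter), an expectation that rests on the first occurrence having given a 1.6-fold higher number from compound 1 to compound 2 (0.20 log units; within the scatter). On that basis compound 4 is expected to give about 20 nM in this assay, with a plausible range from 8 nM to 50 nM.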

Compound 4, half-maximal inhibitory concentration: 63.1 nM
Beside the measured number, compound 4's estimate is 3.2-fold (0.50 log units) below it; the measured number lies above the stated range.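

On the core without fluoro, methylsulfanyl in place of bromo gives a 5.0-fold higher number from compound 3 to compound 4 (0.70 log units; beyond the scatter), so in this assay this swap does not carry over from one core to the other at a constant size: the same change on two cores in this assay, a 1.6-fold higher number (0.20 log units; within the scatter) from compound 1 to compound 2 and a 5.0-fold higher number (0.70 log units; beyond the scatter) from compound 3 to compound 4, 3.2-fold (0.50 log units) apart, beyond the scatter of two such steps

Read along the other edge of the same four compounds, hydrogen in place of fluoro gives a 2.0-fold higher number from compound 2 to compound 4 (0.30 log units; within the scatter), and this step also depends on which group is already present on the other aromatic ring: the same change on two cores in this assay, a 1.6-fold lower number (0.20 log units; within the scatter) from compound 1 to compound 3 and a 2.0-fold higher number (0.30 log units; within the scatter) from compound 2 to compound 4, 3.2-fold (0.50 log units) apart, beyond the scatter of two such steps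

Both comparisons rest on the same four values, so they count as one mismatch seen from two sides rather than two independent findings, and they show that the two changes do not simply add up in this series without showing why, or whether the same holds on any other core.

On these data alone, it remains open whether another group in place of bromo, such as chloro or methoxy, would also respond to the presence of fluoro in the same way. As far as these compounds go, it is equally open whether the mismatch would persist with an amide in place of the carboxylic acid, or whether a repeat measurement of these four compounds would reproduce it.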